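Series notes: phenyl to 4-methoxyphenyl

A few compounds are considered here, and "the series" means these few. Any claim that something is new, unique, unknown or untested is made for them only; others in the source may bear on it.

Of the compounds shown here, three on the shared core have been measured in a functional assay on B16-F10 cells (Mus musculus) for inhibition, read by colorimetric assay and MTT assay, with a stated time of 72 h; a lower number here means a stronger inhibitor, a higher number a weaker inhibitor. Compound 1 `C/C1=C\CC[C@@]2(C)O[C@@H]2[C@H]2OC(=O)[C@@H](CN3CCCC3)[C@@H]2C[C@H]1O` gives 4000 nM, and compound 2 `C/C1=C\CC[C@@]2(C)O[C@@H]2[C@H]2OC(=O)[C@@H](CN(C)CCN(C)C)[C@@H]2C[C@H]1O` gives 4000 nM. Replacing pyrrolidin-1-yl with (2-(dimethylamino)ethyl)(methyl)amino gives no change at the digits printed from compound 1 to compound 2 (within the scatter). Compound 3 `C/C1=C\CC[C@@]2(C)O[C@@H]2[C@H]2OC(=O)[C@@H](CN3CCN(c4ccccc4)CC3)[C@@H]2C[C@H]1O` gives 6000 nM, which lies within the scatter of both other compounds, so the three cannot be ranked.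

Compound 4 `COc1ccc(N2CCN(C[C@@H]3C(=O)O[C@H]4[C@H]3C[C@@H](O)/C(C)=C/CC[C@@]3(C)O[C@H]43)CC2)cc1` differs from compound 3 at one place: methoxy in place of hydrogen on an aromatic carbon. This is methoxy in place of hydrogen on an aromatic carbon, or phenyl to 4-methoxyphenyl. Within the data shown here, no measured pair tests a substituent on this aromatic ring, so the evidence is only indirect. Among the measured compounds shown here, the single measured step, no change at the digits printed from compound 1 to compound 2 (within the scatter), lies at the amine rather than on the ring. For the measured compounds named here, compound 3, the only measured compound with an aromatic ring, also stays within the scatter of the other two at 6000 nM. No step beyond the scatter is therefore expected in this assay, and the data do not set a direction. The expected change is a 1.2-fold lower number from compound 3 to compound 4 (0.08 log units; within the scatter). Compound 4 is estimated at 5000 nM, with an expected range of 2500 nM to 10000 nM.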

Compound 4, half-maximal inhibitory concentration: 14000 nM
Estimate against measurement, compound 4: 2.8-fold (0.45 log units) below, outside the stated range (above it).
By their numbers in this assay, from the lowest: compounds 1, 2 and 3 (each within the scatter of the next); then compound 4.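

In this assay, among these compounds, methoxy in place of hydrogen on an aromatic carbon, para to a large group, gives a 2.3-fold higher number from compound 3 to compound 4 (0.37 log units; beyond the scatter) and so moves the number beyond the scatter, whereas the one earlier step, at the amine, gives no change at the digits printed from compound 1 to compound 2 (within the scatter) and does not. Among the compounds shown here, this is the first sign that the six-membered aromatic ring of carbon only is not a silent place, and on this single pair the change runs toward a weaker inhibitor, by a modest step. Nothing among the data shown bears on what lies behind this step.

One pair cannot tell whether the step belongs to methoxy itself or would follow any group placed on this carbon, and a fluorine, a hydroxyl or a carboxylic acid at the same place would separate those two readings. It also leaves open whether methoxy on another carbon of this ring, or a longer alkoxy chain such as ethoxy at this one, would move the number in the same direction.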